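Swapping the sulfonyl substituent in a stable series

The compounds below may be only part of what the source reports. "The series", "measured", "known", "first", "only" and "open" are said of these compounds alone.

Of the compounds shown here, three sharing one core have been measured in an ADME assay on microsomes from liver (Homo sapiens) for metabolic stability, with a stated time of 10 min; on this read-out higher numbers stand for a more stable compound and lower numbers for a less stable compound. Compound 1 `CC(C)OC(=O)NCCS(=O)(=O)NC(=O)c1ccc(Nc2nc(NC3(c4ccc(Cl)cc4)CC3)nc(OCC(F)(F)F)n2)cc1` gives 100% in this assay. Compound 2 `Cc1ccccc1S(=O)(=O)NC(=O)c1ccc(Nc2nc(NC3(c4ccc(Cl)cc4)CC3)nc(OCC(F)(F)F)n2)cc1` gives 100%, and compound 3 `CNC(=O)NCCS(=O)(=O)NC(=O)c1ccc(Nc2nc(NC3(c4ccc(Cl)cc4)CC3)nc(OCC(F)(F)F)n2)cc1` gives 97%. Compound 2 is level with compound 1 at the digits shown, the two together the highest of the three numbers, and its furthest neighbour is compound 3: a number 3 percentage points lower from compound 2 to compound 3 (within the scatter).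

Compound 4 `CC(=O)NCCS(=O)(=O)NC(=O)c1ccc(Nc2nc(NC3(c4ccc(Cl)cc4)CC3)nc(OCC(F)(F)F)n2)cc1` is the next member. Its difference from compound 2 is 2-acetamidoethyl in place of 2-methylphenyl on a sulfonyl sulfur. Going by the values given here, two measured steps bear on this change at the sulfonyl sulfur: no change at the digits printed from compound 1 to compound 2 (within the scatter), and a number 3 percentage points lower from compound 2 to compound 3 (within the scatter). Both replace a substituted ethyl chain with 2-methylphenyl or the reverse, and neither moved this assay beyond the scatter. The step to compound 4 again exchanges 2-methylphenyl for a substituted ethyl chain, so no movement beyond the scatter is expected; the expected step is a number 3 percentage points lower from compound 2 to compound 4 (within the scatter). Compound 4 is therefore estimated at 97%, within a range from 88% to 100%.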

Compound 4, percent of the compound remaining: 95%
Compound 4: the middle estimate sits 2 percentage points above what was measured; low and high end bracket the measured number.
By their numbers in this assay, from the lowest: compounds 4, 3, 1 and 2 (each within the scatter of the next).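

In this assay the exchange of 2-methylphenyl for 2-acetamidoethyl on the sulfonyl sulfur gives a number 5 percentage points lower from compound 2 to compound 4 (within the scatter) and so adds a further ring-free chain that stays within the scatter of the aromatic group. Compound 4 also completes a set of three groups on the carbonyl carbon at the end of the chain: methyl in place of methylamino gives a number 2 percentage points lower from compound 3 to compound 4 (within the scatter) and methyl in place of isopropoxy gives a number 5 percentage points lower from compound 1 to compound 4 (within the scatter) so this read-out does not separate the three. Nothing available here explains even these small differences.

Going by these compounds, whether a free amine or a carboxylic acid at the end of the ethyl chain would move the number beyond the scatter stays open. The same holds for a longer chain on the sulfonyl sulfur.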